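This account rests on a few compounds, and the source may have more. Where it says the series, first, only, none or still open, it means among the compounds named here.

Measured compounds:
Compound 1 `O=c1c(CSC(=S)N2CCCC2)coc2ccccc12` – in a functional assay on LM7 cells (Homo sapiens) for antiproliferative activity, read by MTT assay, with a stated time of 72 h (a lower number here means a stronger inhibitor, a higher number a weaker inhibitor), compound 1 gives 6000 nM.
Compound 2 `Cc1ccc2c(=O)c(CSC(=S)N(C(C)C)C(C)C)coc2c1` – in this assay compound 2 gives 6300 nM.

Compound 2 holds the higher of the two numbers, but its gap to compound 1 lies within the scatter, so the two values are read as equivalent. The untested compound 3 `CC(C)N(C(=S)SCc1coc2ccccc2c1=O)C(C)C` differs from compound 2 by hydrogen in place of methyl on an aromatic carbon. Among the compounds with values here, no step between measured compounds isolates this change, so its effect cannot be read directly. With the two measured values sitting together, the step from compound 2 to compound 3 is expected to be small, with no direction beyond the scatter. Compound 3 is therefore estimated at 6000 nM, in a range from 2500 nM to 15000 nM. This corresponds to an expected step of a 1.1-fold lower number from compound 2 to compound 3 (0.02 log units; within the scatter).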

Compound 3, half-maximal inhibitory concentration: 21900 nM
For compound 3 the middle estimate is 3.7-fold (0.56 log units) below the measured one; measured number outside the range, above it.
By their numbers in this assay, from the lowest: compounds 1 and 2 (each within the scatter of the next); then compound 3.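

In this assay, hydrogen in place of methyl on an aromatic carbon gives a 3.5-fold higher number from compound 2 to compound 3 (0.54 log units; beyond the scatter), so this carbon, meta to a fused ring and para to a fused ring, is not indifferent to the change, and the methyl goes with the lower number. Diisopropylamino in place of pyrrolidin-1-yl on a thiocarbonyl carbon gives a 3.7-fold higher number from compound 1 to compound 3 (0.56 log units; beyond the scatter), so the group at this second place counts as well, with pyrrolidin-1-yl going with the lower number. Nothing shown here accounts for either step.

As far as these compounds go, each change rests on a single pair, so it remains open whether the methyl result holds with pyrrolidin-1-yl in place of diisopropylamino. From the compounds shown here alone, it is also open how a chlorine or a methoxy group on the same aromatic carbon, or a morpholine or diethylamino group on the thiocarbonyl carbon, would compare.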